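The compounds below may be only part of what the source reports. "The series", "measured", "known", "first", "only" and "open" are said of these compounds alone.

Working notes on the series. Compound 1 `Nc1cc(N)c2nc(-c3ccccc3)c(NCc3ccc(Cl)c(Cl)c3)nc2c1` gives 6920 nM in a functional assay on OVCAR-3 cells (Homo sapiens) for inhibition, read by sulforhodamine B assay, with a stated time of 48 h (a higher number here means a weaker inhibitor of growth, a lower number a stronger inhibitor of growth), the lowest number of the three measured and the strongest growth inhibitor here, since compound 2 `CCOC(=O)[C@H](CCC(=O)O)NC(=O)c1ccc(Sc2nc3cc(N)cc(N)c3nc2-c2ccccc2)cc1` with 38000 nM and compound 3 `CCOC(=O)[C@H](CCC(=O)O)NC(=O)c1ccc(Oc2nc3cc(N)cc(N)c3nc2-c2ccccc2)cc1` with 40700 nM both sit beyond the scatter above it. Compound 4 `COc1ccc(CNc2nc3cc(N)cc(N)c3nc2-c2ccccc2)cc1` differs from compound 1 by 4-methoxyphenyl in place of 3,4-dichlorophenyl on a saturated chain carbon bound to a nitrogen on an aromatic ring. Going by the values given here, no measured pair in the set carries this change, so its size is a guess; the benzylamine linkage is kept, and only the substituents on the pendant ring move. A moderate shift is expected, more likely toward a weaker inhibitor than a stronger one, and possibly none beyond the scatter; the estimated step is a 1.6-fold higher number from compound 1 to compound 4 (0.20 log units; within the scatter). For compound 4 the expected value is 11000 nM, with a range from 3500 nM to 35000 nM.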

Compound 4, concentration for total growth inhibition: 7760 nM
Compound 4: the middle estimate sits 1.4-fold (0.15 log units) above what was measured; the range from low to high includes it.
By their numbers in this assay, from the lowest: compounds 1 and 4 (each within the scatter of the next); then compounds 2 and 3 (each within the scatter of the next).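

In this assay, 4-methoxyphenyl in place of 3,4-dichlorophenyl on a saturated chain carbon bound to a nitrogen on an aromatic ring gives a 1.1-fold higher number from compound 1 to compound 4 (0.05 log units; within the scatter) and so stays within the scatter. This single pair shows that the two substituted pendant rings cannot be told apart at this position. No available evidence accounts for this result.

On these data alone, whether an unsubstituted phenyl, a carboxylic acid on the pendant ring or a longer chain at this place would read the same stays open. As far as these compounds go, compounds 2 and 3 differ from compound 1 in more than one place, so the role of the benzylamine linkage also stays open.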